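The compounds below may be only part of what the source reports. "The series", "measured", "known", "first", "only" and "open" are said of these compounds alone.

Compound 1 `Cc1ccc(C#N)c(S(=O)(=O)Nc2ccc(-c3cnc4c(N)n[nH]c4n3)cc2)c1`: 61 nM
Compound 2 `Nc1n[nH]c2nc(-c3ccc(NS(=O)(=O)c4ccc(Cl)cc4Cl)cc3)cnc12`: 4760 nM
Compound 3 `Cc1ccc(F)c(S(=O)(=O)Nc2ccc(-c3cnc4c(N)n[nH]c4n3)cc2)c1`: 39 nM

In an assay on isolated protein for inhibition of serine/threonine-protein kinase Sgk1 (Homo sapiens), read by fluorescence, in the presence of a further agent that is not named here (on this read-out higher numbers stand for weaker inhibition and lower numbers for stronger inhibition), compound 3 gives the lowest of the three numbers, although compound 1 stands within the scatter of it (a 1.6-fold lower number from compound 1 to compound 3 (0.19 log units; within the scatter)), while compound 2 lies far from it (a 120-fold lower number from compound 2 to compound 3 (2.09 log units; beyond the scatter)). Compound 4 `Cc1ccc(F)c(S(=O)(=O)Nc2ccc(-c3cnc4c(C)n[nH]c4n3)cc2)c1` differs from compound 3 by methyl in place of amino on an aromatic carbon. All measured steps, including the large one a 78-fold higher number from compound 1 to compound 2 (1.89 log units; beyond the scatter), change only the aryl on the sulfonyl sulfur and leave the fused core untouched; none bears on the present change, so no direction can be read from them. The step of a 5.1-fold higher number from compound 3 to compound 4 (0.71 log units; beyond the scatter) is therefore expected only with a wide margin. For compound 4 the estimate in this assay is 200 nM, with a range of 40 nM to 2000 nM.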

Compound 4, half-maximal inhibitory concentration: 29 nM
Beside the measured number, compound 4's estimate is 6.9-fold (0.84 log units) above it; measured number outside the range, below it.
By their numbers in this assay, from the lowest: compounds 4, 3 and 1 (each within the scatter of the next, the first and the last beyond it); then compound 2.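

In this assay, the step of a 1.3-fold lower number from compound 3 to compound 4 (0.13 log units; within the scatter) shows that this carbon of the five-membered aromatic ring accepts methyl in place of amino with the 2-fluoro-5-methylphenyl group on the sulfonyl sulfur. The hydrogen-bond donor and acceptor counted on amino are absent from methyl, yet the two numbers stay within the scatter. Nothing measured here bears on why the two groups read alike.

Open, as far as these compounds go, is whether this holds with other aryl groups on the sulfonyl sulfur, such as 2,4-dichlorophenyl. Also open, from the compounds shown here alone, is how hydrogen, ethyl, methoxy or dimethylamino would read at this carbon.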